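This account rests on a few compounds, and the source may have more. Where it says the series, first, only, none or still open, it means among the compounds named here.

Measured so far, in a functional assay (muscle tissue) with Cavia porcellus as the target; on this read-out higher numbers stand for weaker inhibition and lower numbers for stronger inhibition:

- Compound 1 `CO/C(O)=C1/C(C)=NC(C)=C([N+](=O)[O-])C1c1cccc(C)n1` gives 2290 nM.
- Compound 2 `CC1=NC(C)=C([N+](=O)[O-])C(c2ccccn2)/C1=C(/O)OCCc1ccccc1` gives 639 nM.
- Compound 3 `CC1=NC(C)=C([N+](=O)[O-])C(c2ncccc2C(F)(F)F)/C1=C(/O)OCCc1ccccc1` gives no number, only a limit of the assay, > 59800 nM.

Compound 3 therefore stands at the edge of what this assay can report (the limit of > 59800 nM in this assay, at which 1 of the 3 values shown sits); its true value is not known, only that it lies at or beyond that edge. Compound 4 `CC1=NC(C)=C([N+](=O)[O-])C(c2ncccc2[N+](=O)[O-])/C1=C(/O)OCCc1ccccc1` is compound 3 with one change: nitro in place of trifluoromethyl on an aromatic carbon.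

Within the data shown here, only one measured step bears on this change. Going an at least 93-fold higher number from compound 2 to compound 3 (1.97 log units; beyond the scatter), a substituent placed at this position on the pyridine ring of compound 2 led to a very large loss of inhibition. Compound 4 keeps a substituent at that same position and merely swaps one for another. Without any measured swap of this kind, the size of the step cannot be judged, but the expectation is that compound 4 remains a weak inhibitor, near the limit, giving an estimated at least 2.3-fold lower number from compound 3 to compound 4 (0.37 log units; beyond the scatter).

Compound 4 is expected to give about 25000 nM, somewhere between 2500 nM and 120000 nM.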

Compound 4, half-maximal inhibitory concentration: 77700 nM
Compound 4: the middle estimate sits 3.1-fold (0.49 log units) below what was measured; the measured number falls inside the stated range.
By their numbers in this assay, from the lowest: compound 2; then compound 1; then compound 4.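

With nitro in place of hydrogen on this aromatic carbon, this assay shows a 120-fold higher number from compound 2 to compound 4 (2.08 log units; beyond the scatter). The large loss of inhibition seen with trifluoromethyl is therefore not confined to that one group, and this time its size is a real number rather than a limit. Compound 3 carries only a limit, so whether nitro or trifluoromethyl is the worse of the two cannot be read from the step to compound 4: the limit of > 59800 nM in this assay, at which 1 of the 4 values shown sits.

As far as these compounds go, whether an amine, a hydroxyl group or a single fluorine on this same carbon would lose as much inhibition remains open. Also open, from the compounds shown here alone, is whether any group at all can sit here and keep the inhibition of compound 2.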